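Trading a Benzyloxy Group for Ethylsulfanyl

The source may hold more compounds than are shown below. What is called first, only, known or untested is meant among the compounds shown, and "the series" means these compounds.

Compound 1, `N#Cc1c(-c2ccccc2)cc(-c2ccccc2)nc1OCc1ccccc1`: 100 nM
Compound 2, `Cc1cccnc1-c1cc(-c2ccc(F)cc2)c(C#N)c(OCc2cccnc2)n1`: 36 nM

Of the compounds shown here, two have been tested in an assay on isolated protein for inhibition of sulfide:quinone oxidoreductase, mitochondrial (Homo sapiens); a higher number here means a weaker inhibitor, a lower number a stronger inhibitor. Compound 1 gives 100 nM, the higher of the two numbers; compound 2 gives 36 nM, and the gap between them lies beyond the usual scatter. Going by the values given here, the shared core of the pair is otherwise not varied in any single place, so no measured step is available.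

Compound 3, `CCSc1nc(-c2ccccc2)cc(-c2ccccc2)c1C#N`, is yet to be measured. It differs from compound 1 by a single change: ethylsulfanyl in place of benzyloxy on an aromatic carbon. Without a measured step of this kind, the expectation must rest on the loss of a whole aromatic ring in exchange for a short chain. The step from compound 1 to compound 3 is expected to be a 2.5-fold higher number from compound 1 to compound 3 (0.40 log units; beyond the scatter), toward a weaker inhibitor, though the direction is uncertain. Compound 3 is estimated at 250 nM, within a range from 60 nM to 1000 nM.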

Compound 3, half-maximal inhibitory concentration: 132 nM
Compound 3: the middle estimate sits 1.9-fold (0.28 log units) above what was measured; low and high end bracket the measured number.
By their numbers in this assay, from the lowest: compound 2; then compounds 1 and 3 (each within the scatter of the next).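

In this assay, ethylsulfanyl in place of benzyloxy on this aromatic carbon gives a 1.3-fold higher number from compound 1 to compound 3 (0.12 log units; within the scatter) and thus stays within the scatter. At this place, next to the ring nitrogen and ortho to a cyano group, the six-membered aromatic ring of the benzyloxy group can therefore go, along with the oxygen, and the two compounds still cannot be told apart in this assay. Nothing measured here accounts for that outcome.

The exchange alters the linking atom and the group beyond it together, and only a benzylsulfanyl or an ethoxy group at this place would separate the two. From the compounds shown here alone, how an amine or a longer chain on this carbon would read in this assay remains open, as does whether ethylsulfanyl would fare alike on the core of compound 2.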